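One Halogen for Another on the Aromatic Ring

The source may hold more compounds than are shown below. What is called first, only, known or untested is meant among the compounds shown, and "the series" means these compounds.

Two compounds share one core and differ only in the halogen on the aromatic ring. Compound 1 `O=C(CCCCCc1cccc(I)c1)N1CCOC1=O` carries iodo, while compound 2 `O=C(CCCCCc1ccc(Cl)cc1)N1CCOC1=O` carries chloro. In an assay on HEK293 cells for inhibition of N-acylethanolamine-hydrolyzing acid amidase (Rattus norvegicus), read by LC-MS, with a stated time of 30 min (a higher number here means a weaker inhibitor, a lower number a stronger inhibitor), compound 1 gives 3120 nM, and in this assay compound 2 gives 4600 nM. Compound 2 stands at the higher of the two numbers, yet its gap to compound 1 lies within the usual scatter of repeated measurements, so the two values cannot be told apart.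

Compound 3 `O=C(CCCCCc1ccc(Br)cc1)N1CCOC1=O` is the next step from compound 2. The change is bromo in place of chloro on an aromatic carbon, with bromo taking the place of chloro on an aromatic carbon of a six-membered aromatic ring of carbon only, para to a large group.

Going by the values given here, no step between measured compounds isolates this kind of swap, so the expectation rests on how close compounds 1 and 2 sit. With a chloro and an iodo at this place giving values within the scatter of each other, the step of a 1.3-fold lower number from compound 2 to compound 3 (0.12 log units; within the scatter) is expected to be small, none beyond the scatter, in either direction. Compound 3 is therefore expected to give about 3500 nM, with a range from 1500 nM to 8000 nM.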

Compound 3, half-maximal inhibitory concentration: 8510 nM
Estimate against measurement, compound 3: 2.4-fold (0.39 log units) below, outside the stated range (above it).
By their numbers in this assay, from the lowest: compounds 1, 2 and 3 (each within the scatter of the next, the first and the last beyond it).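

Going by these compounds alone, this is the first measured pair that differs in one place alone, so it gives a direct reading of a single halogen swap on an aromatic carbon para to a large group: in this assay the change is a 1.9-fold higher number from compound 2 to compound 3 (0.27 log units; within the scatter) and stays within the usual scatter of repeated measurements. Compound 2 and compound 3 therefore cannot be told apart, and at this place on the ring, chloro and bromo are not separated by this measurement, even though bromine is a different atom from chlorine. Nothing measured here bears on why the two compounds read alike, so the result describes this one pair and offers no explanation.

As far as these compounds go, whether any group at this place can move the number beyond the scatter stays open, since an amine, a carboxylic acid or a methoxy group there would differ from chloro and bromo far more than the two halogens differ from each other. Also open, from the compounds shown here alone, is how the number responds to a change elsewhere in the shared core, such as a longer chain between the aromatic ring and the carbonyl.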